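Notes on compound 3: dimethylamino in place of trifluoromethoxy

The compounds below may be only part of what the source reports. "The series", "measured", "known", "first", "only" and "open" are said of these compounds alone.

Compound 1 `Cc1cccc(-c2nc3ccc(C)cc3c(=O)[nH]2)c1` and compound 2 `Cc1ccc2c(=O)[nH]c(-c3ccccc3OC(F)(F)F)nc2c1` share a core and differ in the substituted pendant ring. In an assay on isolated protein for inhibition of DNA topoisomerase 1 (Homo sapiens), with a stated time of 30 min, tested at 20 uM (on this read-out lower numbers stand for a weaker effect and higher numbers for a stronger effect at the one concentration tested), compound 1 gives 12.7%, while compound 2 gives 100%, the higher of the two numbers, with compound 1 lower by a margin beyond the scatter. Compound 3 `Cc1ccc2c(=O)[nH]c(-c3ccccc3N(C)C)nc2c1` keeps the core of compound 2 and differs by dimethylamino in place of trifluoromethoxy on an aromatic carbon. For the measured compounds named here, no single-change step between measured compounds is available here, so the size of the move in this assay is uncertain; a fall beyond the scatter is expected. Compound 3 is estimated at 70% (range 30% to 100%), an expected step of a number 30 percentage points lower from compound 2 to compound 3 (beyond the scatter).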

Compound 3, a percentage reported as inhibition, at one concentration (the size of the read-out at that concentration, not a potency): 5.3%
For compound 3 the middle estimate is 64.7 percentage points above the measured one; measured number below the stated range.
By their numbers in this assay, from the lowest: compounds 3 and 1 (each within the scatter of the next); then compound 2.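

For the compounds shown here, with the shared core held fixed, dimethylamino in place of trifluoromethoxy gives, in this assay, a number 94.7 percentage points lower from compound 2 to compound 3 (beyond the scatter) and provides the first single-change step. The high read-out of compound 2 therefore does not survive every exchange at this aromatic carbon, and this one position can decide the result. No measurement available here accounts for the step. Still open, from the compounds shown here alone, is how methoxy, trifluoromethyl or a lone fluorine would read at this place, and whether any of them would keep the read-out of compound 2.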